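The source may report more compounds than this note shows. Statements on the series, on what has been measured and on what is new or still open speak of the compounds shown alone.

Of the compounds shown here, two with the same core have been tested in a functional assay on the whole organism for inhibition, with Rattus norvegicus as the target, read by paw edema, with a stated time of 30 min, at a dose of 20 mg/kg by the oral route; a higher number here means a stronger effect of the compound at the dose given, a lower number a weaker effect. Compound 1, `Brc1ccc(OCC2=NCCO2)cc1`, carries a bromo on its aromatic ring, and in this assay compound 1 gives 35.5%. Compound 2, `Fc1ccc(OCC2=NCCO2)cc1`, carries a fluoro at the same place, and in this assay compound 2 gives 18.5%. Among the compounds with values here, the single step between them, a number 17 percentage points lower from compound 1 to compound 2 (beyond the scatter), shows that swapping the halogen changed the read-out more than chance alone would. Within the data shown here, on the two numbers known, compound 2 stands lowest, with compound 1 as its only neighbour.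

Compound 3, `O=[N+]([O-])c1ccc(OCC2=NCCO2)cc1`, is the next compound, and it differs from compound 2 as follows: nitro in place of fluoro on an aromatic carbon. Among the measured compounds shown here, no measured step involves a nitro, so the only guide is that the one swap seen, from bromo to fluoro, moved the number by a modest amount. For compound 3 an increase is expected rather than a drop, but of a size that may well stay within the scatter, an expected a number 9.5 percentage points higher from compound 2 to compound 3 (within the scatter). Compound 3 is therefore estimated at 28%, with a range from 10% to 46%.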

Compound 3, a percentage reported as inhibition, in the whole organism at one dose (the size of the read-out at that dose, not a potency): 29.2%
Compound 3: the middle estimate sits 1.2 percentage points below what was measured; the range from low to high includes it.
By their numbers in this assay, from the lowest: compound 2; then compounds 3 and 1 (each within the scatter of the next).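

The step from fluoro to nitro on the aromatic carbon (a number 10.7 percentage points higher from compound 2 to compound 3 (beyond the scatter)) shows that the low number of compound 2 does not hold for every replacement of bromo at this place, and compound 2 now sits apart from both other compounds in this assay. The step from bromo to nitro (a number 6.3 percentage points lower from compound 1 to compound 3 (within the scatter)) leaves compound 1 and compound 3 indistinguishable in this read-out, even though nitro brings three heavy atoms and two hydrogen-bond acceptors, so a larger group with acceptors at this place neither clearly helps nor clearly harms relative to bromo. Nothing measured here explains why fluoro stands apart from the other two groups.

Within the data shown here, with only three groups compared at one place and at a single dose, it remains open whether fluoro is an isolated case or part of a wider trend. A methyl, a methoxy or an amine at the same place, or the plain ring with only hydrogen there, could show whether such compounds fall with compound 2 or with compound 1 and compound 3.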